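A pyridin-3-yl swap at the assay limit

A few compounds are considered here, and "the series" means these few. Any claim that something is new, unique, unknown or untested is made for them only; others in the source may bear on it.

Compound 1 (`CC(C)n1ccc2c(C(=O)Nc3ccccn3)cc(-c3cccs3)nc21`) and compound 2 (`CC(C)n1ccc2c(C(=O)Nc3ccc(F)cc3)cc(-c3cccs3)nc21`) share a core and were tested in an ADME assay on LLC-MK2 cells (Macaca mulatta) for cytotoxicity, read by spectrophotometry and crystal violet staining, with a stated time of 4 days; a higher number here means that more compound is tolerated, a lower number that less compound is tolerated. Compound 1 gives > 200000 nM, which is a limit and not a number. Compound 2 gives > 200000 nM, which is also a limit. Compound 2 therefore has no exact value, and the data so far stop at the limit of > 200000 nM in this assay, at which 2 of the 2 values shown sit.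

Compound 3 (`CC(C)n1ccc2c(C(=O)Nc3cccnc3)cc(-c3cccs3)nc21`) carries pyridin-3-yl in place of 4-fluorophenyl on an amide-type nitrogen. For the measured compounds named here, the one measured change of this kind is a step that the two limits leave unreadable from compound 1 to compound 2, which put 4-fluorophenyl in place of pyridin-2-yl at that same nitrogen. It offers no size to carry over, so no step beyond the scatter is expected in this assay. The expected change is a number no higher from compound 2 to compound 3 (the limit leaves the size open). For compound 3 the estimated value is 200000 nM, with an expected range from 100000 nM to 400000 nM.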

Compound 3, half-maximal cytotoxic concentration: 25000 nM
Compound 3: the middle estimate sits 8.0-fold (0.90 log units) above what was measured; the measured number lies below the stated range.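

In this assay, for the compounds shown here, the group on this amide-type nitrogen now shows a readable effect for the first time: pyridin-3-yl in place of 4-fluorophenyl gives an at least 8.0-fold lower number from compound 2 to compound 3 (0.90 log units; beyond the scatter). Pyridin-3-yl in place of pyridin-2-yl gives an at least 8.0-fold lower number from compound 1 to compound 3 (0.90 log units; beyond the scatter), so these two pyridine groups are not interchangeable here, and a six-membered aromatic ring with a hetero atom does not by itself set the outcome. Both step sizes are minimums rather than exact sizes, and the true gaps could be larger: the limit of > 200000 nM in this assay, at which 2 of the 3 values shown sit.

From the compounds shown here alone, it remains open whether this lower tolerance is particular to pyridin-3-yl or would also appear with pyridin-4-yl, or with a phenyl ring carrying an amine or a carboxylic acid. The compounds shown give no cause for the drop.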